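The source may report more compounds than this note shows. Statements on the series, on what has been measured and on what is new or still open speak of the compounds shown alone.

Working notes on the series.

Three compounds carry the shared core with a substituent on the saturated chain carbon bound to an amine nitrogen and a carbonyl carbon. Compound 1 `C[C@H](NCc1ccc(OCc2ccc([N+](=O)[O-])cc2)cc1)C(N)=O` has methyl there and a nitro-bearing benzyl ether; in an assay on mitochondria for inhibition of Amine oxidase [flavin-containing] A (Rattus norvegicus), tested at 100 uM (a higher number here means more inhibition at the concentration tested (going by the name of the read-out), a lower number less inhibition), compound 1 gives 22%. Compound 2 `NC(=O)[C@H](CO)NCc1ccc(OCc2ccc(Cl)cc2)cc1` has hydroxymethyl and a chloro-bearing benzyl ether; in this assay compound 2 gives 47%. Compound 3 `NC(=O)[C@@H](NCc1ccc(OCc2ccc(Cl)cc2)cc1)c1ccccc1` has phenyl on the same carbon and the same chloro-bearing ether; in this assay compound 3 gives 27%. Compound 3 therefore stands second of the three: compound 2 sits higher, while the values of compound 3 and compound 1 lie within the scatter of one another. Within the data shown here, the one measured step at this position, a number 20 percentage points lower from compound 2 to compound 3 (beyond the scatter), is modest.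

Compound 4 `C[C@H](NCc1ccc(OCc2ccc(Cl)cc2)cc1)C(N)=O` is the next point. Its change from compound 3 is methyl in place of phenyl on a saturated chain carbon bound to an amine nitrogen and a carbonyl carbon. Among the measured compounds shown here, compound 1 carries methyl at the same place, though with a different ether, and the step from compound 2 to compound 3 is the only direct guide. No shown step pairs phenyl against methyl, so a step within or near the scatter is expected, with the direction open. The estimated step of a number 3 percentage points higher from compound 3 to compound 4 (within the scatter) is expected to be small. For compound 4 in this assay an estimated 30% is expected, within 15% to 48%.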

Compound 4, a percentage reported as inhibition, at one concentration (the size of the read-out at that concentration, not a potency): 37%
Compound 4: the middle estimate sits 7 percentage points below what was measured, within the range that was stated.
By their numbers in this assay, from the lowest: compounds 1, 3, 4 and 2 (each within the scatter of the next, the first and the last beyond it).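

With the chloro-bearing ether held constant, a number 10 percentage points higher from compound 3 to compound 4 (within the scatter) and a number 10 percentage points lower from compound 2 to compound 4 (within the scatter) place methyl within the scatter of both phenyl and hydroxymethyl in this assay, although those two groups are separated by a number 20 percentage points lower from compound 2 to compound 3 (beyond the scatter). The change of chloro in place of nitro on an aromatic carbon, with methyl held on the chain carbon, gives a number 15 percentage points higher from compound 1 to compound 4 (beyond the scatter) and is the only step shown at that aromatic carbon. No measured evidence bears on the reason for these numbers.

The compounds shown leave open how an amine or a longer chain on the saturated chain carbon would read in this assay. They also leave open whether the chloro over nitro step would recur with hydroxymethyl or phenyl on that carbon, and how a methoxy group would compare at the aromatic carbon.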